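Dimethoxyphenyl on the amine nitrogen: expected loss of potency

The compounds below may be only part of what the source reports. "The series", "measured", "known", "first", "only" and "open" are said of these compounds alone.

Compound 3 `COc1ccc(S(=O)(=O)c2nc3ccccc3nc2Nc2ccccc2)cc1` holds the lower of the two numbers available in a functional assay on HCT-116 cells (Homo sapiens) for cytotoxicity, read by MTT assay, with a stated time of 72 h (a higher number here means a weaker inhibitor, a lower number a stronger inhibitor), where compound 3 gives 1260 nM. Its nearest neighbour is compound 1 `O=S(=O)(c1ccccc1)c1nc2ccccc2nc1Nc1ccccc1`, which in this assay gives 1630 nM; the step of a 1.3-fold lower number from compound 1 to compound 3 (0.11 log units; within the scatter) is within the scatter, so the two are not separated. Compound 2 `COc1cc(Nc2nc3ccccc3nc2S(=O)(=O)c2ccc(C)cc2)cc(OC)c1` gives in this assay only a limit, > 50000 nM, as recorded in the limit of > 50000 nM in this assay, at which 1 of the 3 values shown sits. Compound 4 `COc1ccc(S(=O)(=O)c2nc3ccccc3nc2Nc2cc(OC)cc(OC)c2)cc1` differs from compound 3 by 3,5-dimethoxyphenyl in place of phenyl on a nitrogen on an aromatic ring. Going by the values given here, no single measured step covers this change; compound 2, which also carries 3,5-dimethoxyphenyl on a nitrogen, sits at the limit, whereas compound 1 and compound 3 with phenyl give numbers. A large rise is therefore expected in this assay, with compound 4 estimated at 30000 nM (range 7000 nM to 150000 nM), a step of a 24-fold higher number from compound 3 to compound 4 (1.38 log units; beyond the scatter), quite possibly reaching the limit.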

Compound 4, half-maximal inhibitory concentration: 13400 nM
The estimate for compound 4 lay 2.2-fold (0.35 log units) above the measured number, within the range that was stated.
By their numbers in this assay, from the lowest: compounds 3 and 1 (each within the scatter of the next); then compound 4. At a limit, above all of these: compound 2.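

In this assay, 3,5-dimethoxyphenyl in place of phenyl on a nitrogen on an aromatic ring now has a measured cost: an 11-fold higher number from compound 3 to compound 4 (1.03 log units; beyond the scatter). Compound 4 still gives a number, so this group alone does not carry a compound to the limit, and methoxy in place of methyl on an aromatic carbon gives an at least 3.7-fold lower number from compound 2 to compound 4 (0.57 log units; beyond the scatter). Compound 2 remains a limit, not a number: the limit of > 50000 nM in this assay, at which 1 of the 4 values shown sits.

Whether one methoxy on that phenyl accounts for the loss remains open. So does the effect of an amine or a carboxylic acid on that ring.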